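This account rests on a few compounds, and the source may have more. Where it says the series, first, only, none or still open, it means among the compounds named here.

Of the compounds shown here, three sharing one core have been measured in an ADME assay for permeability, using PAMPA, with a stated time of 30 min, at pH 7.4; a higher number here means that the compound crosses the layer faster, a lower number that the compound crosses the layer more slowly. Compound 1 `Fc1ccc(-c2ccc3c(NCCCNCc4ccco4)ccnc3c2)cc1` gives 237 10^-6 cm/s. Compound 3 `FC(F)(F)c1ccc(-c2ccc3c(NCCCNCc4ccco4)ccnc3c2)cc1` gives 237 10^-6 cm/s in this assay. Compound 2 `COc1cccc(CNCCCNc2ccnc3cc(-c4ccc(C(F)(F)F)cc4)ccc23)c1O` gives 237 10^-6 cm/s in this assay, so compound 2 stands level with compound 1 and compound 3, all three sitting at the same figure. Compound 4 `COc1cccc(CNCCCNc2ccnc3cc(Cc4ccc(F)cc4Cl)ccc23)c1O` has not yet been measured. It differs from compound 2 in one place: 2-chloro-4-fluorobenzyl in place of 4-(trifluoromethyl)phenyl on an aromatic carbon. Among the compounds with values here, none of the measured steps covers exactly this exchange, so the nearest guides are the two steps already seen. The step of no change at the digits printed from compound 1 to compound 3 (within the scatter) and the step of no change at the digits printed from compound 2 to compound 3 (within the scatter) each stayed within the scatter, and the three measured compounds give the same reading, which suggests this assay has been insensitive to the changes seen so far. Compound 4 is therefore expected to show a step of no change at the digits printed from compound 2 to compound 4 (within the scatter), nothing beyond the scatter. The estimate for compound 4 in this assay is 237 10^-6 cm/s, with a likely range from 120 10^-6 cm/s to 470 10^-6 cm/s.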

Compound 4, apparent permeability: 23 10^-6 cm/s
Beside the measured number, compound 4's estimate is 10-fold (1.01 log units) above it; measured number outside the range, below it.
By their numbers in this assay, from the lowest: compound 4; then compounds 1, 2 and 3 (each within the scatter of the next).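

In this assay, within the data shown here, the aromatic carbon of the shared core that carries these groups proves sensitive: putting 2-chloro-4-fluorobenzyl in place of 4-(trifluoromethyl)phenyl gives a 10-fold lower number from compound 2 to compound 4 (1.01 log units; beyond the scatter), whereas the earlier steps, no change at the digits printed from compound 1 to compound 3 (within the scatter) and no change at the digits printed from compound 2 to compound 3 (within the scatter), stayed within the scatter. Both groups contain one six-membered aromatic ring of carbon only and have no hydrogen-bond donors or acceptors, so a large step occurred even with those counts matched. No measurement shown explains the drop.

This single exchange alters the link to the ring and the ring's substituents together, so the compounds shown cannot say which of these changes matters. Going by these compounds, an unsubstituted benzyl group at the same carbon would help to separate the two, and whether the step also holds with the furan-2-yl side chain of compound 3 remains open.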